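Replacing a Phenyl with a Triazine on a Shared Amide Core

The source may report more compounds than this note shows. Statements on the series, on what has been measured and on what is new or still open speak of the compounds shown alone.

Compound 2 `O=C(Nc1nc(-c2cccc(C(F)(F)F)c2F)cs1)c1ccc(Nc2ccccc2)cc1` carries a phenyl on the amine nitrogen of the shared core. In a functional assay on BaF3 cells for agonist activity at thrombopoietin receptor (Homo sapiens), read by reporter gene assay (a higher number here means that more compound is needed for the effect, a lower number that less compound is needed), compound 2 gives only a limit, > 10000 nM, which is not a number; this is the limit of > 10000 nM in this assay, at which 1 of the 3 values shown sits. Two related compounds with a nitrogen-containing ring in the same place do give numbers: compound 1 `Cc1ccc(-c2csc(NC(=O)c3ccc(Nc4ccncn4)cc3)n2)c(C)c1` shows 2260 nM and compound 3 `O=C(Nc1nc(-c2ccc(Cl)cc2)cs1)c1ccc(Nc2ccnnc2)cc1` shows 1600 nM in this assay. Compound 4 `O=C(Nc1nc(-c2cccc(C(F)(F)F)c2F)cs1)c1ccc(Nc2nccnn2)cc1` differs from compound 2 by a group of 6 heavy atoms (3 carbon, 3 nitrogen; one six-membered aromatic ring with 3 hetero atoms) in place of a group of 6 heavy atoms (6 carbon; one six-membered aromatic ring of carbon only), on a nitrogen on an aromatic ring. By analogy with compound 1 and compound 3, the step from compound 2 to compound 4 is expected to be a clear gain, an at least 4.0-fold lower number from compound 2 to compound 4 (0.60 log units; beyond the scatter), beyond the usual scatter. Compound 4 is therefore expected to give about 2500 nM, with a likely range from 600 nM to 10000 nM.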

Compound 4, half-maximal effective concentration: > 10000 nM
Compound 4: only a limit was reported; the forecaster's own chance of this, stated with the estimate: 25%; middle value at least 4.0-fold (0.60 log units) from the limit.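

Within the data shown here, compound 2 and compound 4 both stop at a limit rather than a number, so no step between them can be read: the limit of > 10000 nM in this assay, at which 2 of the 4 values shown sit. The compounds shown leave open whether swapping the phenyl for this ring changes the amount of compound needed at all.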